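Acid-bearing side chains on the shared core

The source may hold more compounds than are shown below. What is called first, only, known or untested is meant among the compounds shown, and "the series" means these compounds.

Compound 3 `O=C(O)CCCCCOc1ccc2cc1COC/C=C/COCc1cccc(c1)-c1ccnc(n1)N2` gives 45000 nM in an assay on Sf9 cells for inhibition of protein deacetylase HDAC6 (Homo sapiens), read by fluorescence, with a stated time of 2 h (on this read-out lower numbers stand for stronger inhibition and higher numbers for weaker inhibition), the higher of the two numbers recorded; compound 1 `O=C(NO)c1ccc(NCCOc2ccc3cc2COC/C=C/COCc2cccc(c2)-c2ccnc(n2)N3)cc1` gives 395 nM. Compound 2 `O=C(O)c1ccc(OCCOc2ccc3cc2COC/C=C/COCc2cccc(c2)-c2ccnc(n2)N3)cc1` gives > 100000 nM, which is a limit of the assay and not a number (the limit of > 100000 nM in this assay, at which 1 of the 3 values shown sits). Compound 4 `O=C(O)c1cccc(NCCOc2ccc3cc2COC/C=C/COCc2cccc(c2)-c2ccnc(n2)N3)c1` differs from compound 3 by (3-carboxyphenyl)amino in place of 3-carboxypropyl on a saturated chain carbon, two bonds along the chain from an oxygen on an aromatic ring. The measured steps that bear on this change are a 110-fold higher number from compound 1 to compound 3 (2.06 log units; beyond the scatter) and an at least 2.2-fold lower number from compound 2 to compound 3 (0.34 log units; beyond the scatter): the hydroxamic acid stood far apart, while the acid on a chain ran somewhat lower than the acid on an aromatic ring. Compound 4 keeps a carboxylic acid and restores an aromatic group with an amine. For compound 4 the expected step is a 1.8-fold higher number from compound 3 to compound 4 (0.25 log units; within the scatter), with the number likely near or at the limit. The estimate for compound 4 is 80000 nM, ranging from 20000 nM to 300000 nM.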

Compound 4, half-maximal inhibitory concentration: 53000 nM
Beside the measured number, compound 4's estimate is 1.5-fold (0.18 log units) above it; the range from low to high includes it.
By their numbers in this assay, from the lowest: compound 1; then compounds 3 and 4 (each within the scatter of the next). At a limit, above all of these: compound 2.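

In this assay, (3-carboxyphenyl)amino in place of 3-carboxypropyl on a saturated chain carbon, two bonds along the chain from an oxygen on an aromatic ring gives a 1.2-fold higher number from compound 3 to compound 4 (0.07 log units; within the scatter), so these two groups are not told apart at this place. With the amine nitrogen kept, 3-carboxyphenyl in place of 4-(hydroxycarbamoyl)phenyl gives a 130-fold higher number from compound 1 to compound 4 (2.13 log units; beyond the scatter), so the amine with an aromatic ring does not by itself carry the number of compound 1. Compound 2 stands at a limit: the limit of > 100000 nM in this assay, at which 1 of the 4 values shown sits.

(3-carboxyphenyl)amino in place of 4-carboxyphenoxy gives an at least 1.8-fold lower number from compound 2 to compound 4 (0.27 log units; that floor lies within the scatter), so this step, taken from a limit, does not tell these two groups apart.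

Open, going by these compounds, is whether a hydroxamic acid on the chain of compound 3 reaches the number of compound 1. Also open, on these data alone, is what a hydroxamic acid does in place of the carboxylic acid of compound 4.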